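The source may report more compounds than this note shows. Statements on the series, on what has been measured and on what is new or still open speak of the compounds shown alone.

The series holds three measured compounds and one awaiting measurement, all tested in an assay for displacement of a labelled ligand from protein deacetylase HDAC6 (Homo sapiens), read by fluorescence polarization, with a stated time of 10 min; a higher number here means a weaker inhibitor, a lower number a stronger inhibitor. Compound 1 `Cc1n[nH]c(=O)nc1Nc1ccc(C(C)C)cc1` gives "not active" (no number reported) in this assay. Compound 2 `O=C(O)CCc1nc2ccccc2nc1OCc1ccccn1` gives 270000 nM, and compound 3 `O=C(O)CCn1nc(-c2cccnc2)ccc1=O` gives 350000 nM. Compound 2 carries the lower of the two reported numbers, but its gap to compound 3 lies within the usual scatter of repeated measurements, so the two cannot be ranked against each other, and compound 1 contributes no number at all. Every measured compound is thus a very weak inhibitor at best.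

Compound 4 `O=C(O)CCc1nc2ccccc2nc1OCCOc1ccccn1` differs from compound 2 in one place: ((pyridin-2-yl)oxy)methyl in place of pyridin-2-yl on a saturated chain carbon bound to an oxygen on an aromatic ring. Among the compounds with values here, no pair of measured compounds shows the effect of a change of this kind, so no measured step can serve as a guide. Because compound 2 gives 270000 nM and compound 3 gives 350000 nM in this assay, the numbers in hand sit close together and far from potency, and a small step with no direction beyond the scatter is expected, namely a 1.1-fold higher number from compound 2 to compound 4 (0.05 log units; within the scatter). For compound 4 in this assay the estimate is 300000 nM, with a range from 100000 nM to 1000000 nM, and a fair chance remains that only a limit is reported.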

Compound 4, half-maximal inhibitory concentration: 110000 nM
Compound 4: middle estimate off by 2.7-fold (0.44 log units), on the high side, within the range that was stated.
By their numbers in this assay, from the lowest: compound 4; then compounds 2 and 3 (each within the scatter of the next).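

Within the data shown here, putting ((pyridin-2-yl)oxy)methyl in place of pyridin-2-yl on a saturated chain carbon bound to an oxygen on an aromatic ring gives the first step that can be read: in this assay it yields a 2.5-fold lower number from compound 2 to compound 4 (0.39 log units; beyond the scatter), a modest change but one beyond the scatter. The position therefore accepts the longer group, which keeps one six-membered aromatic ring with 1 hetero atom and holds 2 hydrogen-bond acceptors where pyridin-2-yl holds 1, and the number moves in the favourable direction, although compound 4 at 110000 nM remains a very weak inhibitor. Nothing measured here accounts for the step, so it stands as an observation about this single pair.

The compounds shown leave open whether the step belongs to the added oxygen, to the added chain carbon, or to the new distance of the pyridine ring from the core, a question that an amine in place of that oxygen or a plain carbon chain of the same length could address. They also leave open whether a still longer chain would extend the step, and whether the carboxylic acid shared by compound 2 and compound 4 contributes to the weak binding seen for both.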